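The source may hold more compounds than are shown below. What is called first, only, known or untested is meant among the compounds shown, and "the series" means these compounds.

Measured so far in a functional assay on Hep 3B2 cells (Homo sapiens) for antiproliferative activity, read by MTT assay, with a stated time of 24 h, tested at 100 ug/mL; a lower number here means a weaker effect, a higher number a stronger effect of the compound at the concentration tested:

Compound 1 `CCc1ccc2nc(C(=O)Nc3c(F)cc(-c4cccc(F)c4)cc3F)c(C)c(O)c2c1` gives 63.2%.
Compound 2 `Cc1c(C(=O)Nc2c(F)cc(-c3cccc(F)c3)cc2F)nc2ccc(OC(F)(F)F)cc2c1O` gives 80.3%.

Among the measured compounds shown here, compound 2 stands highest of these two numbers, and the single step measured so far, a number 17.1 percentage points higher from compound 1 to compound 2 (beyond the scatter), lies beyond the scatter. That step exchanged an ethyl for a trifluoromethoxy group on the shared core.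

Compound 3 `Cc1c(C(=O)Nc2c(F)cc(-c3cccc(F)c3)cc2F)nc2ccc(C(F)(F)F)cc2c1O` is the next compound to be measured. Its change from compound 2 is trifluoromethyl in place of trifluoromethoxy on an aromatic carbon. This keeps a fluorinated group at the same place and removes only the oxygen that linked it to the ring. For the measured compounds named here, no measured step tests that removal, so the one step known gives only a loose guide; a small change in this assay, likely within the scatter, is expected. Compound 3 is therefore estimated at about 74%, with a range from 58% to 90%, the expected step being a number 6.3 percentage points lower from compound 2 to compound 3 (within the scatter).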

Compound 3, a percentage reported as inhibition, at one concentration (the size of the read-out at that concentration, not a potency): 68.4%
Compound 3: the middle estimate sits 5.6 percentage points above what was measured, and the stated range covers the measured number.
By their numbers in this assay, from the lowest: compounds 1 and 3 (each within the scatter of the next); then compound 2.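

In this assay removing only the oxygen that links the fluorinated group to the ring gives a number 11.9 percentage points lower from compound 2 to compound 3 (beyond the scatter) and so shows that trifluoromethoxy and trifluoromethyl are not interchangeable at this position. Trifluoromethyl in place of ethyl gives a number 5.2 percentage points higher from compound 1 to compound 3 (within the scatter) and so cannot be told apart from the usual spread of repeated measurements. Among these three compounds, only compound 2 stands clear of the others, and the oxygen is the one atom that separates it from compound 3.

As far as these compounds go, whether a methoxy group, which keeps the oxygen but carries no fluorine, or an amine at this place would match compound 2 stays open. Nothing shown here offers an explanation for the difference the oxygen makes.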